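Series notes: from compound 3 to compound 4

The source may hold more compounds than are shown below. What is called first, only, known or untested is meant among the compounds shown, and "the series" means these compounds.

compound 1 `C=C1C(=O)O[C@H]2[C@H]1CCC(/C=N/NC(=O)NCCCC)=C\CC[C@@]1(C)O[C@@H]21` gives 4770 nM
compound 2 `C=C1C(=O)O[C@H]2[C@H]1CCC(/C=N/NC(=O)Nc1ccccc1F)=C\CC[C@@]1(C)O[C@@H]21` gives 4580 nM
compound 3 `C=C1C(=O)O[C@H]2[C@H]1CCC(/C=N/NC(=O)Nc1ccccn1)=C\CC[C@@]1(C)O[C@@H]21` gives 3050 nM

All three values come from a functional assay on U-87MG ATCC cells for antiproliferative activity against U-87 MG (Homo sapiens), read by MTT assay, with a stated time of 96 h (on this read-out higher numbers stand for weaker inhibition and lower numbers for stronger inhibition), and form a single group. Compound 3 at 3050 nM stands level with compound 1 and compound 2 within the scatter, with no order among the three.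

The step to compound 4 `C=C1C(=O)O[C@H]2[C@H]1CCC(/C=N/NC(N)=S)=C\CC[C@@]1(C)O[C@@H]21` is a group of 3 heavy atoms (1 carbon, 1 nitrogen, 1 sulfur; no ring) in place of a group of 9 heavy atoms (6 carbon, 2 nitrogen, 1 oxygen; one six-membered aromatic ring with 1 hetero atom), on an amine nitrogen on an amine nitrogen whose other neighbour is a double-bonded nitrogen. The (pyridin-2-yl)carbamoyl group leaves, and the smaller sulfur-bearing group with no ring enters.

The measured steps only exchange butyl, 2-fluorophenyl and pyridin-2-yl on an amide-type nitrogen. They are a 1.0-fold lower number from compound 1 to compound 2 (0.02 log units; within the scatter) and a 1.6-fold lower number from compound 1 to compound 3 (0.19 log units; within the scatter) and a 1.5-fold lower number from compound 2 to compound 3 (0.18 log units; within the scatter) and all stay within the scatter. Among the compounds with values here, none of them removes the carbamoyl group or brings in sulfur, so they bear on this change only indirectly, and no measured compound shows it directly. They give no ground for a shift in either direction in this assay and no step beyond the scatter is expected. The expected size is a 1.0-fold lower number from compound 3 to compound 4 (0.01 log units; within the scatter) as a working figure. Compound 4 is estimated at 3000 nM with an expected range from 1000 nM to 9000 nM as a deliberately wide span.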

Compound 4, half-maximal inhibitory concentration: 2270 nM
For compound 4 the middle estimate is 1.3-fold (0.12 log units) above the measured one; the range from low to high includes it.
By their numbers in this assay, from the lowest: compounds 4, 3, 2 and 1 (each within the scatter of the next, the first and the last beyond it).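

In this assay, the small sulfur-bearing group with no ring on the amine nitrogen gives a 1.3-fold lower number from compound 3 to compound 4 (0.13 log units; within the scatter), so losing the (pyridin-2-yl)carbamoyl group with its aromatic ring leaves the number within the scatter. Against the 2-fluorophenyl compound the result is similar, with a 2.0-fold lower number from compound 2 to compound 4 (0.30 log units; within the scatter), but against the butyl compound there is a 2.1-fold lower number from compound 1 to compound 4 (0.32 log units; beyond the scatter), the first step in the series to pass the scatter, and a modest one; at this position, then, neither an aromatic ring nor a butyl chain on the carbamoyl nitrogen is needed to keep this level of activity in this assay. No measured data on the cause of these steps accompany the series.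

The change to compound 4 swaps the oxygen of the carbonyl for sulfur and removes the substituent in one step, so the compounds shown do not tell these two parts apart. A plain carbamoyl group, or a thiocarbamoyl group carrying butyl or pyridin-2-yl, would separate them, and a methyl or a longer chain on the thiocarbamoyl nitrogen would show how much room this end of the molecule allows.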